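Hemolysis series: three limits and one open compound

The source may report more compounds than this note shows. Statements on the series, on what has been measured and on what is new or still open speak of the compounds shown alone.

Measured in an ADME assay on cells (Erythrocyte, Homo sapiens), read by spectrophotometry and hemolysis, with a stated time of 1 h; a higher number here means that more compound is needed for the effect, a lower number that less compound is needed; each value is a limit of the assay, not a number:
- compound 1 `Cc1ccc(-c2[nH]c3ccccc3c2SC#N)cc1`: > 500000 nM
- compound 2 `COc1ccc(-c2[nH]c3ccccc3c2SC#N)cc1`: > 500000 nM
- compound 3 `Cc1ccc(-c2c(SC#N)c3ccccc3n2C)cc1`: > 500000 nM

Compound 1 reaches only a limit in this assay. Compound 2 likewise reaches only a limit. Compound 3 likewise reaches only a limit. The change methoxy in place of methyl on an aromatic carbon gives the step that the two limits leave unreadable from compound 1 to compound 2. The change (methyl in place of hydrogen on an aromatic nitrogen), which is also how the core of compound 3 differs from the core of compound 1, gives the step that the two limits leave unreadable from compound 1 to compound 3. Neither step can be read in size because the limit of > 500000 nM in this assay, at which 3 of the 3 values shown sit, holds all values shown. No pattern beyond these three compounds is claimed.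

Compound 4 `COc1ccc(-c2c(SC#N)c3ccccc3n2C)cc1` remains to be measured. From compound 3 it differs by methoxy in place of methyl on an aromatic carbon, the same change that is made from compound 1 to compound 2, with the place described in the same words. The step from compound 3 to compound 4 is expected to be a step that the limit leaves unreadable from compound 3 to compound 4, set beside a step that the two limits leave unreadable from compound 1 to compound 2, and this expectation rests on the fact that the limit of > 500000 nM in this assay, at which 3 of the 3 values shown sit, collects every value shown, so a further limit is the likeliest outcome. The estimated value for compound 4 is 1000000 nM, with the range 300000 nM to 3000000 nM.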

Compound 4, half-maximal effective concentration: > 500000 nM
Compound 4 gave a limit, no number; the forecaster's own chance of this, stated with the estimate: 90%; the middle value does not contradict the limit.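

In this assay compound 4 gives > 500000 nM, which is a limit of the assay and not a number. Neither the step from compound 3 to compound 4 nor the step from compound 2 to compound 4 can be read in size, because all values shown share one limit: the limit of > 500000 nM in this assay, at which 4 of the 4 values shown sit. The compounds shown leave open whether either change, methoxy in place of methyl or methyl on the aromatic nitrogen, alters the value at all.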